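The source may hold more compounds than are shown below. What is called first, only, known or untested is meant among the compounds shown, and "the series" means these compounds.

Measured in an ADME assay on Caco-2 cells (Homo sapiens) for permeability, in the apical to basolateral direction; a higher number here means that the compound crosses the layer faster, a lower number that the compound crosses the layer more slowly:

- Compound 1 `CC(C)COc1ncc(-c2cn(C)c3cc(C(=O)NS(C)(=O)=O)ccc23)cc1Cl`: < 15 nm/s, a limit
- Compound 2 `CC(C)Cc1ccc(-c2cn(C)c3cc(C(=O)NS(C)(=O)=O)ccc23)cc1`: < 15 nm/s, a limit
- Compound 3 `CC(C)COc1ncc(-c2cn(C)c3cc(C(=O)NS(=O)(=O)C4CC4)c(F)cc23)cc1Cl`: 34 nm/s

Going by the values given here, compound 3 gives 34 nm/s, the only true number in this small set. Compound 1 and compound 2 both stand at the limit of < 15 nm/s in this assay, at which 2 of the 3 values shown sit.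

Compound 4 `CC(C)COc1ncc(-c2cn(C)c3cc(C(=O)NS(C)(=O)=O)c(F)cc23)cc1Cl` carries methyl in place of cyclopropyl on a sulfonyl sulfur, a change counted as methyl in place of cyclopropyl on a sulfonyl sulfur. Compound 1 and compound 2 also carry methylsulfonyl, and both stand at the limit of < 15 nm/s in this assay, at which 2 of the 3 values shown sit, so a downward move is expected in this assay. The expected change is a 2.1-fold lower number from compound 3 to compound 4 (0.33 log units; beyond the scatter). For compound 4 the estimate is 16 nm/s, with an expected range from 8 nm/s to 34 nm/s.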

Compound 4, apparent permeability: 20 nm/s
For compound 4 the middle estimate is 1.3-fold (0.10 log units) below the measured one, within the range that was stated.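

In this assay, the change from cyclopropyl to methyl on a sulfonyl sulfur now has a true number at both ends, and the step is modest: a 1.7-fold lower number from compound 3 to compound 4 (0.23 log units; within the scatter). Fluoro in place of hydrogen on an aromatic carbon can be read only against the limit held by compound 1, as an at least 1.3-fold higher number from compound 1 to compound 4 (0.12 log units; that floor lies within the scatter). Compound 4 carries methylsulfonyl yet gives 20 nm/s, so it goes against the pairing of that group seen in compound 1 and compound 2 with: the limit of < 15 nm/s in this assay, at which 2 of the 4 values shown sit.

The compounds shown leave open how a longer chain or an amine on the sulfonyl sulfur would read in this assay.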